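The source may report more compounds than this note shows. Statements on the series, on what has been measured and on what is new or still open speak of the compounds shown alone.

Working notes on a small set of bis-sulfonamides tested in an assay for binding affinity to protein lin-28 homolog A (Mus musculus), with a stated time of 1 h; on this read-out higher numbers stand for weaker inhibition and lower numbers for stronger inhibition.

Compound 1 `O=S(=O)(Nc1ccccc1NS(=O)(=O)c1ccc(F)cc1)c1ccc(F)cc1` gives 28300 nM in this assay. Compound 2 `O=S(=O)(Nc1ccccc1NS(=O)(=O)c1ccc(Cl)cc1)c1ccc(Cl)cc1` gives 27500 nM in this assay; how the core of compound 2 differs from the core of compound 1 is not broken down here, and the two values lie within the scatter of each other, so nothing can be read from the pair. Compound 3 `Cc1ccc(NS(=O)(=O)c2ccc(F)cc2)c(NS(=O)(=O)c2ccc(F)cc2)c1` carries one extra group on the core of compound 1, the change being (methyl in place of hydrogen on an aromatic carbon). In this assay compound 3 gives 16200 nM, and the step is a 1.7-fold lower number from compound 1 to compound 3 (0.24 log units; within the scatter), which remains within the scatter.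

Compound 4 `Cc1ccc(NS(=O)(=O)c2ccc(Cl)cc2)c(NS(=O)(=O)c2ccc(Cl)cc2)c1` has not yet been measured. It differs from compound 2 by methyl in place of hydrogen on an aromatic carbon, the same change that separates compound 3 from compound 1, made at a place described in the same words. Going by the values given here, the only reference for this change is a single pair, so the expectation is weak. Among the compounds with values here, a step of a 1.6-fold lower number from compound 2 to compound 4 (0.21 log units; within the scatter) is expected, because the same change gave a 1.7-fold lower number from compound 1 to compound 3 (0.24 log units; within the scatter) and no other pair in the set speaks to it. Compound 4 is therefore estimated at 17000 nM in this assay, with a range from 9000 nM to 33000 nM, a range that overlaps the value of compound 2 given the scatter of such measurements.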

Compound 4, half-maximal inhibitory concentration: 28400 nM
Estimate against measurement, compound 4: 1.7-fold (0.22 log units) below, and the stated range covers the measured number.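

Carried to the core of compound 2, methyl in place of hydrogen on an aromatic carbon gives in this assay a 1.0-fold higher number from compound 2 to compound 4 (0.01 log units; within the scatter) and so no readable change on that core. Neither step with this change lies beyond the scatter, so the set does not show that the methyl shifts the number on either core, and it gives no sign that the change behaves differently from one core to the other; equally, two pairs this small cannot establish that the change is transferable in general. Set side by side, the two steps agree as far as such measurements allow: the same change on two cores in this assay, a 1.7-fold lower number (0.24 log units; within the scatter) from compound 1 to compound 3 and a 1.0-fold higher number (0.01 log units; within the scatter) from compound 2 to compound 4, 1.8-fold (0.26 log units) apart, within the scatter of two such steps.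

The compounds shown carry only hydrogen or methyl at this place on the core, and only fluorine or chlorine on the two aromatic rings attached through the sulfonyl groups, so the reach of this comparison ends there. As far as these compounds go, whether a different group at the same place, such as an amine, a carboxylic acid or a longer chain, would give a step beyond the scatter on either core remains open.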